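The source may hold more compounds than are shown below. What is called first, only, known or untested is meant among the compounds shown, and "the series" means these compounds.

Measured so far in a functional assay for antagonist activity at C-X-C chemokine receptor type 3 (Homo sapiens); a lower number here means a stronger inhibitor, a higher number a weaker inhibitor:
Compound 1, `CNC(=O)c1cnc(N2CCN(C3CCN(Cc4ccc(Cl)cc4)CC3)[C@@H](C)C2)c(Cl)c1`: 32 nM
Compound 2, `CNC(=O)c1cnc(N2CCN(C3CCN(Cc4ccc[nH]4)CC3)[C@@H](C)C2)c(Cl)c1`: 8060 nM
Compound 3, `CNC(=O)c1cnc(N2CCN(C3CCN(Cc4ccc(Cl)cc4F)CC3)[C@@H](C)C2)c(Cl)c1`: 18 nM

Compound 1 holds the second highest of the three numbers. Its nearest neighbour is compound 3, reached by a step that stays within the scatter, a 1.8-fold lower number from compound 1 to compound 3 (0.25 log units; within the scatter). The large movement in the series comes from the other end of the molecule: a 250-fold higher number from compound 1 to compound 2 (2.40 log units; beyond the scatter) and, back again, a 450-fold lower number from compound 2 to compound 3 (2.65 log units; beyond the scatter). Both of these steps concern the group on the saturated chain carbon bound to an amine nitrogen in a ring, not the amide side of the core.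

Compound 4, `CCNC(=O)c1cnc(N2CCN(C3CCN(Cc4ccc(Cl)cc4)CC3)[C@@H](C)C2)c(Cl)c1`, differs from compound 1 in one place: methyl in place of hydrogen on a saturated chain carbon bound to an amide-type nitrogen. Among the compounds with values here, none of the measured steps touches this carbon, so the series gives no direct guide to the size or direction of this change; the amide substituent is held constant in compounds 1, 2 and 3. Within the data shown here, with no step bearing on it, the working expectation is that the change stays within the scatter, the estimated step being a 1.3-fold higher number from compound 1 to compound 4 (0.10 log units; within the scatter). Compound 4 is therefore estimated at 40 nM in this assay, with a range from 15 nM to 110 nM.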

Compound 4, half-maximal inhibitory concentration: 2.3 nM
For compound 4 the middle estimate is 17-fold (1.24 log units) above the measured one, and the stated range ends above it.
By their numbers in this assay, from the lowest: compound 4; then compounds 3 and 1 (each within the scatter of the next); then compound 2.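

In this assay, the change from methylcarbamoyl to ethylcarbamoyl gives a 14-fold lower number from compound 1 to compound 4 (1.14 log units; beyond the scatter) and so shows that the amide side of the molecule, held constant in compounds 1, 2 and 3, is not a silent position. Before this, only exchanges of the group on the saturated chain carbon bound to an amine nitrogen in a ring had moved the number beyond the scatter, and those involved whole aromatic groups, whereas here a single added carbon, with no hydrogen-bond donor or acceptor entering, produces a large step towards a lower number. No measurement in hand accounts for the size of this step, so its cause stays unassigned.

Going by these compounds, it remains open whether the number keeps falling or turns back with a longer or branched chain in this place, such as propylcarbamoyl or isopropylcarbamoyl, or with a 2-methoxyethyl group in place of the ethyl. Also open, on these data alone, is whether the ethylcarbamoyl change carries over to the 4-chloro-2-fluorophenyl group of compound 3, since only the 4-chlorophenyl background of compound 1 has been read for it.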